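Cytotoxicity of a triazinylthio-acetanilide series: fluoro for nitro

A few compounds are considered here, and "the series" means these few. Any claim that something is new, unique, unknown or untested is made for them only; others in the source may bear on it.

Measured so far:
compound 1, `O=C(CSc1nncnc1-c1cccc2ccccc12)Nc1ccccc1[N+](=O)[O-]`, 142000 nM
compound 2, `Cc1ccc2sc(NC(=O)CSc3nncnc3-c3ccccc3Cl)nc2c1`, 137000 nM
compound 3, `O=C(CSc1nncnc1-c1ccccc1Cl)Nc1ccccc1[N+](=O)[O-]`, 63000 nM

The three measured compounds were tested in an ADME assay on MT4 cells (Homo sapiens) for cytotoxicity, read by MTT assay; a higher number here means that more compound is tolerated, a lower number that less compound is tolerated. Compound 1 gives the highest number of the three, 142000 nM, though compound 2 at 137000 nM sits within the scatter of it, so no order can be read between those two. Among the measured compounds shown here, compound 3 lies further off: the step of a 2.3-fold lower number from compound 1 to compound 3 (0.35 log units; beyond the scatter) is the only one between two compounds that differ in a single place, and it concerns the aryl group on the shared core, not the anilide end.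

Compound 4, `O=C(CSc1nncnc1-c1cccc2ccccc12)Nc1ccccc1F`, is the next compound to be measured. It differs from compound 1 at the anilide end: fluoro in place of nitro on an aromatic carbon. For the measured compounds named here, no measured step bears on this particular change; the one step that exists, from compound 1 to compound 3, touches a different place and so gives no guidance on the anilide. With nothing in the data pointing either way, the step of a 1.1-fold lower number from compound 1 to compound 4 (0.04 log units; within the scatter) is expected to stay within the scatter, in no particular direction. Compound 4 is therefore estimated at 130000 nM, within a range of 55000 nM to 300000 nM.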

Compound 4, half-maximal cytotoxic concentration: 65000 nM
Compound 4: middle estimate off by 2.0-fold (0.30 log units), on the high side; low and high end bracket the measured number.
By their numbers in this assay, from the lowest: compounds 3 and 4 (each within the scatter of the next); then compounds 2 and 1 (each within the scatter of the next).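

The anilide end of compound 1 turns out to matter in this assay: fluoro in place of nitro, on an aromatic carbon ortho to a large group, gives a 2.2-fold lower number from compound 1 to compound 4 (0.34 log units; beyond the scatter). Among the compounds shown here, until now the only single-place change on record was at the aryl group on the shared core, a 2.3-fold lower number from compound 1 to compound 3 (0.35 log units; beyond the scatter), so this is the first sign that a second site on compound 1 can also shift the tolerated concentration, again modestly and again downward. The change swaps a group of 3 heavy atoms, with 2 hydrogen-bond acceptors, for a single fluorine, but no measurement at hand says what lies behind the lower number.

For the compounds shown here, only this one pair speaks to the change, so it remains open whether fluoro in place of nitro would shift the number in the same way on the 2-chlorophenyl compound 3. Also open, on these data alone, is where an amine, a methoxy group or plain hydrogen at this place would fall, and so whether the lower number follows from losing nitro or from gaining fluoro.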